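Notes on the step from compound 3 to compound 4

A few compounds are considered here, and "the series" means these few. Any claim that something is new, unique, unknown or untested is made for them only; others in the source may bear on it.

Values measured so far in a functional assay (muscle tissue) with Cavia porcellus as the target (on this read-out higher numbers stand for an effect only at larger amounts of compound and lower numbers for an effect already at smaller amounts), are:
Compound 1 `COC(=O)C1=C(C)N=C(C)/C(=C(\O)OC)C1c1ccccc1I` at 46.8 nM
Compound 2 `COC(=O)C1=C(C)N=C(C)/C(=C(\O)OC)C1c1cccc(Br)c1` at 1.29 nM
Compound 3 `COC(=O)C1=C(C)N=C(C)/C(=C(\O)OC)C1c1cc(C)ccc1C` at 100 nM

Compound 3 gives the highest number of the three at 100 nM and is the starting point here. Compound 4 `COC(=O)C1=C(C)N=C(C)/C(=C(\O)OC)C1c1cccc(I)c1` is unmeasured and carries 3-iodophenyl in place of 2,5-dimethylphenyl on a saturated ring carbon. Among the compounds with values here, two measured steps bear on this: a 78-fold higher number from compound 2 to compound 3 (1.89 log units; beyond the scatter) when 2,5-dimethylphenyl replaces 3-bromophenyl, and a 36-fold lower number from compound 1 to compound 2 (1.56 log units; beyond the scatter) when 3-bromophenyl replaces 2-iodophenyl. Within the data shown here, no measured step compares 3-iodophenyl with 3-bromophenyl. A large step to a lower number is nevertheless expected in this assay for this change. The estimated step is a 40-fold lower number from compound 3 to compound 4 (1.60 log units; beyond the scatter) on this reading. For compound 4 the estimated value is 2.5 nM within an expected range from 0.6 nM to 10 nM as a working figure.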

Compound 4, half-maximal effective concentration: 41.7 nM
Compound 4: the middle estimate sits 17-fold (1.22 log units) below what was measured; the measured number lies above the stated range.
By their numbers in this assay, from the lowest: compound 2; then compounds 4 and 1 (each within the scatter of the next); then compound 3.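

In this assay the 3-iodophenyl group does not follow the 3-bromophenyl group: iodo in place of bromo on an aromatic carbon gives (a 32-fold higher number from compound 2 to compound 4 (1.51 log units; beyond the scatter)). With the iodine kept, 3-iodophenyl in place of 2-iodophenyl gives (a 1.1-fold lower number from compound 1 to compound 4 (0.05 log units; within the scatter)), and 3-iodophenyl in place of 2,5-dimethylphenyl gives only (a 2.4-fold lower number from compound 3 to compound 4 (0.38 log units; beyond the scatter)). Nothing at hand accounts for the gap between the bromo and iodo compounds.

Going by these compounds, whether the low number of compound 2 is specific to bromo remains open. A 3-chlorophenyl or 3-methoxyphenyl group on the same saturated ring carbon would help to settle that.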